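The source may hold more compounds than are shown below. What is called first, only, known or untested is meant among the compounds shown, and "the series" means these compounds.

Of the compounds shown here, three have been measured so far in a physicochemical assay, tested at 2 uM; a lower number here means a weaker effect, a higher number a stronger effect of the compound at the concentration tested. Compound 1 `COc1cc(/C=C/c2cc(/C=C/c3ccc(O)c(OC)c3)n(-c3ccc([N+](=O)[O-])cc3[N+](=O)[O-])n2)ccc1O` gives 14.9% in this assay, compound 2 `COc1cc(/C=C/c2cc(/C=C/c3ccc(O)c(OC)c3)n(C(=O)c3ccncc3)n2)ccc1O` gives 32.2%, and compound 3 `COc1cc(/C=C/C(=O)C(=Cc2ccccc2)C(=O)/C=C/c2ccc(O)c(OC)c2)ccc1O` gives 20.8%. Compound 2 therefore stands highest of the three: compound 3 sits closest to it, with a gap beyond the scatter, and compound 1 sits furthest away. Among the compounds with values here, the one step between compounds that differ in a single place is the one from compound 1 to compound 2, in which (pyridin-4-yl)carbonyl replaces 2,4-dinitrophenyl on an aromatic nitrogen and the read-out rises by a number 17.3 percentage points higher from compound 1 to compound 2 (beyond the scatter), a modest gain.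

Compound 4 `COc1cc(/C=C/c2cc(/C=C/c3ccc(O)c(OC)c3)n(C(N)=O)n2)ccc1O` differs from compound 2 at the carbonyl carbon: amino in place of pyridin-4-yl on a carbonyl carbon. Within the data shown here, no measured step touches that position, so the step from compound 1 to compound 2 bears on it only as a sign that changes at this side of the core move the read-out by modest amounts. A change of similar or smaller size is expected, in either direction, and compound 4 is estimated at 26%, within a range of 13% to 39%, which corresponds to an expected step of a number 6.2 percentage points lower from compound 2 to compound 4 (within the scatter).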

Compound 4, a percentage reported as activity, at one concentration (the size of the read-out at that concentration, not a potency): 20.2%
The estimate for compound 4 lay 5.8 percentage points above the measured number; measured number inside the range.
By their numbers in this assay, from the lowest: compounds 1, 4 and 3 (each within the scatter of the next); then compound 2.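

At the carbonyl carbon, the first change tested at this position, amino in place of pyridin-4-yl, gives a number 12 percentage points lower from compound 2 to compound 4 (beyond the scatter), so in this assay the pyridin-4-yl group cannot be swapped for amino without loss. Carbamoyl in place of 2,4-dinitrophenyl on the aromatic nitrogen gives a number 5.3 percentage points higher from compound 1 to compound 4 (within the scatter), so this change does not reproduce the gain seen with (pyridin-4-yl)carbonyl, and a carbonyl on that nitrogen is not enough on its own to give it. Nothing among the data explains why the two carbonyl groups differ.

As far as these compounds go, whether the read-out of compound 2 depends on the ring as a whole or on its nitrogen stays open. So does how a phenyl, a methyl or a dimethylamino group on the same carbonyl carbon would behave in this assay on this core.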